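A few compounds are considered here, and "the series" means these few. Any claim that something is new, unique, unknown or untested is made for them only; others in the source may bear on it.

Compound 1 `FC(F)(F)c1ccc(Nc2ccc(N3CC4CC(C3)N4)cn2)cc1` and compound 2 `Fc1ccc(Nc2ccc(N3CC4CC(C3)N4)cn2)cc1` share one core. Among the compounds with values here, in an assay on HEK293 cells for displacement of a labelled ligand from Neuronal acetylcholine receptor; alpha3/beta4 (Homo sapiens) (a lower number here means a stronger inhibitor, a higher number a weaker inhibitor), compound 1 gives 0.818 nM, while compound 2 gives 13 nM, the highest of the two numbers measured; the only step, a 16-fold higher number from compound 1 to compound 2 (1.20 log units; beyond the scatter), is large. Compound 3 `COc1ccc(Nc2ccc(N3CC4CC(C3)N4)cn2)cc1` differs from compound 2 by methoxy in place of fluoro on an aromatic carbon. Within the data shown here, no measured step involves a methoxy, and the one step that bears on this position shows only that trifluoromethyl gave a far lower number than fluoro. Compound 3 is therefore expected to stay near compound 2, with an estimated 15 nM (range 4 nM to 60 nM), a step of a 1.2-fold higher number from compound 2 to compound 3 (0.06 log units; within the scatter).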

Compound 3, inhibition constant: 9.03 nM
The estimate for compound 3 lay 1.7-fold (0.22 log units) above the measured number; the measured number falls inside the stated range.
By their numbers in this assay, from the lowest: compound 1; then compounds 3 and 2 (each within the scatter of the next).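

In this assay, the exchange of fluoro for methoxy on this aromatic carbon gives a 1.4-fold lower number from compound 2 to compound 3 (0.16 log units; within the scatter), so these two groups cannot be told apart here. Trifluoromethyl now stands apart from two different groups rather than one, with an 11-fold higher number from compound 1 to compound 3 (1.04 log units; beyond the scatter), so the low number of compound 1 no longer rests on the comparison with fluoro alone. No measurement shown accounts for this difference. Still open, as far as these compounds go, is whether the low number is particular to trifluoromethyl or would also appear with a nitrile, an amine or a carboxylic acid at this place.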